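Trading a Four-Membered Ring for an Open Chain

The source may report more compounds than this note shows. Statements on the series, on what has been measured and on what is new or still open speak of the compounds shown alone.

Of the compounds shown here, two have been measured so far, compound 1 `CC1(C(=O)NCCSc2nonc2/C(=N/O)Nc2ccc(F)c(C(F)F)c2)CCN1` and compound 2 `CS(=N)(=O)CC(=O)NCCSc1nonc1/C(=N/O)Nc1ccc(F)c(Br)c1`. In an ADME assay on microsomes from liver (Homo sapiens) for metabolic stability (on this read-out lower numbers stand for a shorter-lived compound and higher numbers for a longer-lived compound), compound 1 gives 1.97 h and compound 2 gives 2.65 h. These two values lie within the scatter of each other, so the data do not set compound 1 apart from compound 2.

Compound 3 `CC(C)(O)CC(=O)NCCSc1nonc1/C(=N/O)Nc1ccc(F)c(C(F)F)c1` has not yet been measured. It keeps the core of compound 1 and differs in one place: a group of 5 heavy atoms (4 carbon, 1 oxygen; no ring) in place of a group of 5 heavy atoms (4 carbon, 1 nitrogen; one four-membered non-aromatic ring with 1 hetero atom), on a carbonyl carbon. The entering group is 2-hydroxy-2-methylpropyl, which has no ring, while the leaving group holds a four-membered non-aromatic ring.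

For the measured compounds named here, no measured step speaks directly to this change. The expectation therefore rests on compound 1 at 1.97 h and compound 2 at 2.65 h, and no shift beyond the scatter is expected in this assay, in either direction. The estimate amounts to an expected step of a 1.2-fold higher number from compound 1 to compound 3 (0.07 log units; within the scatter), which stays inside the scatter. In this assay, compound 3 is estimated at 2.3 h, with an expected range of 1.2 h to 4.4 h.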

Compound 3, half-life: 0.937 h
Compound 3: middle estimate off by 2.5-fold (0.39 log units), on the high side; measured number outside the range, below it.
By their numbers in this assay, from the lowest: compound 3; then compounds 1 and 2 (each within the scatter of the next).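

For the compounds shown here, on the carbonyl carbon, the open-chain 2-hydroxy-2-methylpropyl group in place of the group holding the four-membered ring gives a 2.1-fold lower number from compound 1 to compound 3 (0.32 log units; beyond the scatter) in this assay, the first reading of a single change, and it shows that this position registers on the read-out, if only modestly. The two groups match in the counts computed for them, with the same number of heavy atoms, one hydrogen-bond donor, one hydrogen-bond acceptor and no net charge, so those counts do not separate compound 1 from compound 3, and the difference lies in the ring and in nitrogen against oxygen. Nothing available gives a measured reason for the step.

This single step cannot separate the opening of the ring from the exchange of nitrogen for oxygen; an open-chain amine or an oxetane at the same place would pull the two apart. From the compounds shown here alone, whether the step carries over to a core holding bromine, as in compound 2, instead of the difluoromethyl group also remains open.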